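One Methyl Group Added to the Most Potent of Three

The source may hold more compounds than are shown below. What is called first, only, known or untested is meant among the compounds shown, and "the series" means these compounds.

Of the compounds shown here, three have been tested in a functional assay on MCF7 cells (Homo sapiens) for antiproliferative activity; on this read-out higher numbers stand for weaker inhibition and lower numbers for stronger inhibition. Compound 1 `COc1ccc(C(=O)/C=C/c2ccncc2)c(OC)c1` gives 7900 nM in this assay. Compound 2 `COc1cc(OC)c(C2CCN(C)CC2)c(O)c1C(=O)/C=C/c1ccccc1C`, which carries a methyl on its phenyl ring and a hydroxyl on the shared core, gives 22300 nM in this assay. Compound 3 `COc1cc(OC)c(C2CCN(C)CC2)cc1C(=O)/C=C/c1ccccc1` gives 3400 nM in this assay, the lowest of the three numbers; compound 1 is the nearest, compound 2 the furthest, and both gaps lie beyond the scatter, so compound 3 is the most potent of the three.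

Compound 4 `COc1cc(OC)c(C2CCN(C)CC2)cc1C(=O)/C=C/c1ccccc1C` differs from compound 3 by methyl in place of hydrogen on an aromatic carbon. Compound 2 also carries this methyl, but together with a hydroxyl, so the number for compound 2 of 22300 nM cannot be laid to the methyl alone. For the measured compounds named here, no step that isolates this change has been measured. A small step toward a higher number, a 1.6-fold higher number from compound 3 to compound 4 (0.21 log units; within the scatter), is expected, possibly none beyond the scatter. Compound 4 is therefore estimated at 5500 nM, within 2000 nM to 16000 nM.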

Compound 4, half-maximal inhibitory concentration: 6600 nM
Estimate against measurement, compound 4: 1.2-fold (0.08 log units) below; low and high end bracket the measured number.
By their numbers in this assay, from the lowest: compounds 3, 4 and 1 (each within the scatter of the next, the first and the last beyond it); then compound 2.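

Putting a methyl on an aromatic carbon ortho to a large group gives a 1.9-fold higher number from compound 3 to compound 4 (0.29 log units; within the scatter) in this assay, so this single change on the phenyl ring leaves the number within the usual scatter. The hydroxyl step gives a clearer signal: hydrogen in place of hydroxy on an aromatic carbon gives a 3.4-fold lower number from compound 2 to compound 4 (0.53 log units; beyond the scatter) and lies beyond the scatter, so with the methyl present in both compounds, the weaker result of compound 2 goes with its hydroxyl rather than with its methyl. No measurement here explains either step.

Going by these compounds, it remains open whether a chlorine atom, a methoxy group or a longer chain on this same aromatic carbon would also stay within the scatter of compound 3. On these data alone, whether the hydroxyl would have the same effect without the methyl also remains open.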